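This account rests on a few compounds, and the source may have more. Where it says the series, first, only, none or still open, it means among the compounds named here.

Measured compounds: compound 1 `O=C(Nc1cccc(-n2cc(-c3ccncc3)c(-c3cc(O)cc(Cl)c3)n2)c1)Nc1ccc(Cl)c(Cl)c1`, compound 2 `COc1cc(Cl)cc(-c2nn(-c3cccc(NC(=O)Nc4cc(C(F)(F)F)cc(C(F)(F)F)c4)c3)cc2-c2ccncc2)c1`, compound 3 `COc1cc(Cl)cc(-c2nn(-c3cccc(NC(=O)Nc4ccc(Cl)c(Cl)c4)c3)cc2-c2ccncc2)c1`.

In a functional assay on NCI-H522 cells (Homo sapiens) for inhibition, read by sulforhodamine B assay, with a stated time of 48 h, tested at 0.01 uM (on this read-out lower numbers stand for a stronger effect and higher numbers for a weaker effect at the one concentration tested), compound 1 gives 88%, compound 2 gives 93% and compound 3 gives 95%. Within the data shown here, compound 3 thus sits within the scatter of both compound 2 and compound 1; the only single-point step among them, a number 7 percentage points higher from compound 1 to compound 3 (within the scatter), also lies within the scatter. Compound 4 `COc1cc(Cl)cc(-c2nn(-c3cccc(NC(=O)c4cccc(C(F)(F)F)c4)c3)cc2-c2ccncc2)c1` differs from compound 3 in one place: 3-(trifluoromethyl)phenyl in place of (3,4-dichlorophenyl)amino on a carbonyl carbon. No measured step touches this position, so nothing shown bears directly on it; all that is known is that every compound so far gives a weak effect in this assay . Compound 4 is therefore expected to change little, with a number 5 percentage points lower from compound 3 to compound 4 (within the scatter) not beyond the scatter, giving an estimate of 90%, between 72% and 102%.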

Compound 4, a percentage reported as activity, at one concentration (the size of the read-out at that concentration, not a potency): 51%
Compound 4: the middle estimate sits 39 percentage points above what was measured; the whole stated range lies above it.
By their numbers in this assay, from the lowest: compound 4; then compounds 1, 2 and 3 (each within the scatter of the next).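

In this assay, the change on the carbonyl carbon gives a number 44 percentage points lower from compound 3 to compound 4 (beyond the scatter), so this position, unlike the methyl in place of hydrogen on the oxygen, can move the read-out beyond the scatter. Among these compounds, the single step swaps the amino nitrogen, the two chlorines and the trifluoromethyl together, and it cannot separate their contributions. No measurement shown accounts for the step. Going by these compounds, it remains open whether a plain phenyl, a benzyl or a cyclohexyl on that carbonyl carbon would give a similar number, and whether the step would hold with a hydroxyl in place of the methoxy.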